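This account rests on a few compounds, and the source may have more. Where it says the series, first, only, none or still open, it means among the compounds named here.

Among the three measured compounds, compound 3, `OC(Cc1ccccc1)CN1CCC(NCCSC(c2ccc(F)cc2)c2ccc(F)cc2)CC1`, gives the lowest number: in an assay on membranes from striatum (strain Sprague-Dawley) for displacement of a labelled ligand from sodium-dependent dopamine transporter (Rattus norvegicus), read by scintillation counting, with a stated time of 120 min (on this read-out lower numbers stand for stronger inhibition and higher numbers for weaker inhibition), compound 3 gives 31.4 nM. Compound 1, `Fc1ccc(C(SCCNC2CCN(Cc3ccccc3)CC2)c2ccc(F)cc2)cc1`, gives 32.9 nM, and a 1.0-fold lower number from compound 1 to compound 3 (0.02 log units; within the scatter), so the two sit together. Compound 2, `Fc1ccc(C(SCCNC2CCN(Cc3ccc(C(F)(F)F)cc3)CC2)c2ccc(F)cc2)cc1`, gives 190 nM, and a 6.1-fold lower number from compound 2 to compound 3 (0.78 log units; beyond the scatter), while a 5.8-fold higher number from compound 1 to compound 2 (0.76 log units; beyond the scatter).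

Compound 4, `O=C(c1cc2ccccc2o1)N1CCC(NCCSC(c2ccc(F)cc2)c2ccc(F)cc2)CC1`, differs from compound 3 in one place: (1-benzofuran-2-yl)carbonyl in place of 2-hydroxy-3-phenylpropyl on an amine nitrogen in a ring. The measured steps bear on this only partly. They show that exchanging one group on this nitrogen for another can leave the number almost unchanged, as in a 1.0-fold lower number from compound 1 to compound 3 (0.02 log units; within the scatter), or shift it modestly, as in a 6.1-fold lower number from compound 2 to compound 3 (0.78 log units; beyond the scatter). Among the measured compounds shown here, no measured step puts a carbonyl group on this nitrogen or removes the hydrogen-bond donor counted here, so the direction of the step is open; a modest rise toward weaker inhibition seems the more likely outcome, with wide uncertainty.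

Compound 4 is therefore expected to give about 90 nM in this assay, with a range from 20 nM to 400 nM, which means an estimated 2.9-fold higher number from compound 3 to compound 4 (0.46 log units; beyond the scatter).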

Compound 4, inhibition constant: 115 nM
Compound 4: the middle estimate sits 1.3-fold (0.11 log units) below what was measured, and the stated range covers the measured number.
By their numbers in this assay, from the lowest: compounds 3 and 1 (each within the scatter of the next); then compounds 4 and 2 (each within the scatter of the next).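

A carbonyl group on this amine nitrogen is new here, and the entering (1-benzofuran-2-yl)carbonyl group counts no hydrogen-bond donor, yet inhibition in this assay remains measurable in the same broad range. The change gives a 3.7-fold higher number from compound 3 to compound 4 (0.56 log units; beyond the scatter), and replacing benzyl gives a 3.5-fold higher number from compound 1 to compound 4 (0.54 log units; beyond the scatter), so these steps are modest rather than large. Replacing 4-(trifluoromethyl)benzyl gives a 1.7-fold lower number from compound 2 to compound 4 (0.22 log units; within the scatter), which places compound 2 and compound 4 together.

The compounds shown leave open whether the carbonyl or the benzofuran ring accounts for the step, a question that a (1-benzofuran-2-yl)methyl group or a benzoyl group on this nitrogen would help separate. No measured evidence here explains the step.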